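Swapping a Furan for a Hydroxyphenyl: Expected Cytotoxicity

A few compounds are considered here, and "the series" means these few. Any claim that something is new, unique, unknown or untested is made for them only; others in the source may bear on it.

Of the compounds shown here, three sharing a boron-containing core have been tested in an ADME assay on L929 cells (Mus musculus) for cytotoxicity, read by resazurin assay, with a stated time of 72 h; a lower number here means a stronger inhibitor, a higher number a weaker inhibitor. Compound 1 `O=C(/C=C/c1ccc2c(c1)B(O)OC2)c1ccc(OCc2ccccc2)cc1` reaches only the assay limit, giving > 10 ug/mL. Compound 3 `O=C(CCc1ccc2c(c1)B(O)OC2)c1ccccc1` likewise gives only the limit, > 10 ug/mL. Compound 2 `O=C(/C=C/c1ccc2c(c1)B(O)OC2)c1ccco1` stands at the same place: in this assay compound 2 gives only the limit > 10 ug/mL, so no true number is known for it, and the limit of > 10 ug/mL in this assay, at which 3 of the 3 values shown sit, describes the whole set. Compound 4 `O=C(/C=C/c1ccc2c(c1)B(O)OC2)c1cccc(O)c1` differs from compound 2 in one place: 3-hydroxyphenyl in place of furan-2-yl on a carbonyl carbon. Within the data shown here, no measured step accompanies this change, so the expectation rests on the shared limit alone. The step from compound 2 to compound 4 is expected to be a step that the limit leaves unreadable from compound 2 to compound 4, none beyond the scatter. Compound 4 is therefore estimated at 15 ug/mL, between 8 ug/mL and 40 ug/mL.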

Compound 4, half-maximal inhibitory concentration: 7.56 ug/mL
The estimate for compound 4 lay 2.0-fold (0.30 log units) above the measured number; the measured number lies below the stated range.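

The 3-hydroxyphenyl group on this carbonyl carbon gives the only true number in this assay, where the other compounds shown stop at a limit. The change gives an at least 1.3-fold lower number from compound 2 to compound 4 (0.12 log units; that floor lies within the scatter). That is only a floor, so the real step may be larger and its size stays unknown: the limit of > 10 ug/mL in this assay, at which 3 of the 4 values shown sit.

Going by these compounds, whether the number comes from the hydroxyl or from the six-membered aromatic ring stays open. So does what an amine or a carboxylic acid in place of that hydroxyl would give.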